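A few compounds are considered here, and "the series" means these few. Any claim that something is new, unique, unknown or untested is made for them only; others in the source may bear on it.

In a functional assay on HepG2 cells (Homo sapiens) for inhibition, read by MTT assay, with a stated time of 48 h (on this read-out higher numbers stand for weaker inhibition and lower numbers for stronger inhibition), compound 1, `CCSc1nnc(-c2cc(OC)c(OC)c(OC)c2)n1-c1ccc(OC)cc1`, gives only a limit of the assay, > 60000 nM. Its counterpart compound 2, `COc1ccc(C(=O)CSc2nnc(-c3cc(OC)c(OC)c(OC)c3)n2-c2ccc(OC)cc2)cc1`, gives a measured value in this assay of 18100 nM. Compound 3, `COc1ccc(-n2c(SCC(=O)C3CC3)nnc2-c2cc(OC)c(OC)c(OC)c2)cc1`, again reaches only the limit of this assay, > 60000 nM. The unmeasured compound 4, `COc1ccc(-n2c(SCC(=O)Nc3ccc(Cl)cc3)nnc2-c2cc(OC)c(OC)c(OC)c2)cc1`, differs from compound 1 by (4-chlorophenyl)carbamoyl in place of methyl on a saturated chain carbon bound to a sulfur.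

For the measured compounds named here, two measured steps bear on this change. The step of an at least 3.3-fold lower number from compound 1 to compound 2 (0.52 log units; beyond the scatter) shows that placing an aromatic carbonyl group at this position lowers the number, whereas the step that the two limits leave unreadable from compound 1 to compound 3 leaves the effect of a cyclopropylcarbonyl group unreadable, and the step of an at least 3.3-fold higher number from compound 2 to compound 3 (0.52 log units; beyond the scatter) marks the aromatic substituent as the one that matters, within what the limit of > 60000 nM in this assay, at which 2 of the 3 values shown sit, allows to be read. Compound 4 carries an aromatic ring on an amide rather than a ketone, so a step of similar size and direction is expected, namely an at least 3.0-fold lower number from compound 1 to compound 4 (0.47 log units; beyond the scatter). On this basis compound 4 is estimated at 20000 nM, with a likely range from 6000 nM to 60000 nM, and a fair chance that this assay again reports only a limit.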

Compound 4, half-maximal inhibitory concentration: > 60000 nM
Compound 4: a limit, no number; the forecaster's own chance of this, stated with the estimate: 35%; middle value at least 3.0-fold (0.47 log units) from the limit.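

The result shows that an aromatic ring at this position is not enough to carry the gain seen with compound 2: in this assay, replacing 4-methoxyphenyl on the carbonyl carbon with (4-chlorophenyl)amino gives an at least 3.3-fold higher number from compound 2 to compound 4 (0.52 log units; beyond the scatter). Among the compounds shown, compound 2 alone now gives a measured value, so the aromatic ketone stands apart from the aromatic amide of compound 4. The steps to compound 4 from compound 1 and from compound 3 cannot be read, and the result is bounded by a single ceiling: the limit of > 60000 nM in this assay, at which 3 of the 4 values shown sit.

The change from compound 2 to compound 4 alters both the link to the ring and the group on the ring, so the compounds shown do not separate the two. A (4-methoxyphenyl)carbamoyl or a (4-chlorophenyl)carbonyl group on the saturated chain carbon bound to a sulfur remains an open case.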